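The source may report more compounds than this note shows. Statements on the series, on what has been measured and on what is new or still open speak of the compounds shown alone.

Compound 1 `CN1CCN(CC#Cc2cc3ncnc(Nc4ccc(OCc5cccc(F)c5)c(Cl)c4)c3s2)CC1`: 11 uM
Compound 2 `CN(C)CC#Cc1cc2ncnc(Nc3ccc(OCc4cccc(F)c4)c(Cl)c3)c2s1`: > 32 uM (a limit)

In an ADME assay on HepG2 cells (Homo sapiens) for cytotoxicity (on this read-out lower numbers stand for higher toxicity in this test and higher numbers for lower toxicity in this test), compound 2 stands at > 32 uM, which is a limit of the assay and not a number. Compound 3 `COCC#Cc1cc2ncnc(Nc3ccc(OCc4cccc(F)c4)c(Cl)c3)c2s1` carries methoxy in place of dimethylamino on a saturated chain carbon bound to a triple-bonded carbon. Within the data shown here, the only measured step at this place is an at least 2.9-fold higher number from compound 1 to compound 2 (0.46 log units; beyond the scatter), which is beyond the scatter and replaces a different group. It gives only indirect guidance, so no move towards higher toxicity is assumed. The estimated step is a number no higher from compound 2 to compound 3 (the limit leaves the size open), and no change beyond the scatter is expected in this assay. For compound 3 the expected value is 32 uM, with an estimated range from 13 uM to 64 uM.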

Compound 3, half-maximal toxic concentration: > 33 uM
Compound 3: a limit, no number; the forecaster's own chance of this, stated with the estimate: 60%; at least 1.0-fold (0.01 log units) between middle value and limit.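

In this assay compound 3 gives > 33 uM, which is a limit of the assay and not a number. Methoxy in place of 4-methylpiperazin-1-yl gives an at least 3.0-fold higher number from compound 1 to compound 3 (0.47 log units; beyond the scatter), so the rise seen with dimethylamino also appears with a group that has no nitrogen. Dimethylamino and methoxy cannot be ranked, and the step between compound 2 and compound 3 cannot be read, because both values are limits: the limit of > 33 uM in this assay, at which 1 of the 3 values shown sits.

Going by these compounds, how far compound 2 and compound 3 lie beyond their limits stays open. On these data alone, it is also open whether a morpholin-4-yl group or a hydroxyl at this place would give a value like that of compound 1 or a limit.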